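Solubility of Two Ureas and One Untested Neighbour

The source may report more compounds than this note shows. Statements on the series, on what has been measured and on what is new or still open speak of the compounds shown alone.

Measured so far in a physicochemical assay for solubility, at pH 2.0; on this read-out lower numbers stand for lower solubility and higher numbers for higher solubility:
- compound 1 (`CCOC(=O)Nc1ccc(Oc2ccc(NC(=O)Nc3cc(C(C)(C)C)nn3C)cc2)cc1`) gives 77 ug/mL
- compound 2 (`Cn1nc(C(C)(C)C)cc1NC(=O)Nc1ccc(Sc2ccncc2)cc1`) gives 1660 ug/mL

Compound 2 holds the higher of these two numbers, and the gap to compound 1 lies beyond the scatter. Compound 3 (`Cn1nc(C(C)(C)C)cc1NC(=O)Nc1ccc(CSc2ccncc2)cc1`) carries ((pyridin-4-yl)sulfanyl)methyl in place of (pyridin-4-yl)sulfanyl on an aromatic carbon. For the measured compounds named here, no measured pair shows this change, so the guide is compound 2 alone (1660 ug/mL), and a small fall, probably within the scatter, is expected. The estimated step runs (a 1.7-fold lower number from compound 2 to compound 3 (0.22 log units; within the scatter)). Compound 3 is expected near (1000 ug/mL), with an estimated range from (300 ug/mL) to (2500 ug/mL).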

Compound 3, solubility: 5160 ug/mL
Estimate against measurement, compound 3: 5.2-fold (0.71 log units) below; the whole stated range lies below it.
By their numbers in this assay, from the lowest: compound 1; then compound 2; then compound 3.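

In this assay, this position, on an aromatic carbon para to a large group, responds to ((pyridin-4-yl)sulfanyl)methyl in place of (pyridin-4-yl)sulfanyl with a 3.1-fold higher number from compound 2 to compound 3 (0.49 log units; beyond the scatter). This one-place change shows that a small alteration to the group at this position can move the read-out, though the step is only modest. Nothing available explains the rise.

On these data alone, whether a longer chain before the sulfur, or an amine nitrogen in place of it, would move the number further stays open. So does whether this single step would hold on another core.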